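This account rests on a few compounds, and the source may have more. Where it says the series, first, only, none or still open, it means among the compounds named here.

In a functional assay (ileum) with Cavia porcellus as the target (on this read-out higher numbers stand for weaker inhibition and lower numbers for stronger inhibition), compound 1 `CCCCCCCC/N=C/N1CCC(C(c2ccccc2)c2ccccc2)CC1` gives 1.8 ug/mL. Two relatives altered near the end of the chain, compound 2 `CC(=O)CCCCCC/N=C/N1CCC(C(c2ccccc2)c2ccccc2)CC1` at 2.2 ug/mL and compound 3 `CC(O)CCCCCC/N=C/N1CCC(C(c2ccccc2)c2ccccc2)CC1` at 1.7 ug/mL, lie within the usual scatter of it, so compound 1 stands in a tight group with no real order among the three.

Compound 4 `CCCCCCCC/N=C/N1CCC(C(c2ccccc2)c2ccc(O)cc2)CC1` keeps the chain of compound 1 and changes an aromatic ring instead: hydroxy in place of hydrogen on an aromatic carbon. In words, this is hydroxy in place of hydrogen on an aromatic carbon, which turns phenyl to 4-hydroxyphenyl.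

Among the measured compounds shown here, no measured step touches that ring, so the evidence is only indirect. The closest parallel is a hydroxy added on the chain, a 1.1-fold lower number from compound 1 to compound 3 (0.02 log units; within the scatter). The acetyl change, a 1.2-fold higher number from compound 1 to compound 2 (0.09 log units; within the scatter), and the step of a 1.3-fold lower number from compound 2 to compound 3 (0.11 log units; within the scatter) complete the picture. All three stay within the scatter, which shows that these chain changes left the number in place but says nothing direct about the ring.

No shift beyond the scatter is therefore expected, and the estimated step, a tentative lean towards weaker inhibition, is a 1.4-fold higher number from compound 1 to compound 4 (0.14 log units; within the scatter). Going by these compounds, for compound 4 the estimated value is 2.5 ug/mL, with an expected range from 0.9 ug/mL to 7 ug/mL, kept wide because the ring is untested.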

Compound 4, half-maximal inhibitory concentration: 0.96 ug/mL
Estimate against measurement, compound 4: 2.6-fold (0.42 log units) above, and the stated range covers the measured number.
By their numbers in this assay, from the lowest: compounds 4, 3, 1 and 2 (each within the scatter of the next, the first and the last beyond it).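

Phenyl to 4-hydroxyphenyl is the first change in this series placed on an aromatic ring rather than on the chain, and in this assay the step is a 1.9-fold lower number from compound 1 to compound 4 (0.27 log units; within the scatter) and so adds a ring position to what the chain changes showed. A hydroxy on this aromatic carbon, para to a large group, therefore keeps inhibition in the same range as compound 1, although a step of this size cannot be counted as a real gain in inhibition. Nothing available here speaks to how the added hydroxy acts on the guinea pig ileum, so the result stands as a number without an explanation.

Open questions remain on the same ring carbon, where a methoxy group, a fluorine atom, an amine or a carboxylic acid could show whether the number moves beyond the scatter or stays where it is. Also open, going by these compounds, is whether the 4-hydroxyphenyl ring would give a similar number when joined to the altered chains of compound 2 and compound 3, or when a second hydroxy sits on the other phenyl ring.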